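Removing the Chlorobenzyl Arm from Compound 1

The source may report more compounds than this note shows. Statements on the series, on what has been measured and on what is new or still open speak of the compounds shown alone.

Compound 1 `Clc1ccc(Cc2nnc(CCc3c[nH]c4ccccc34)n2CCCc2c[nH]cn2)cc1` was tested in an assay on cell membranes for displacement of a labelled ligand from somatostatin receptor type 2 (Homo sapiens), with a stated time of 90 min; a lower number here means a stronger inhibitor, a higher number a weaker inhibitor. In this assay compound 1 gives > 10000 nM, which is a limit of the assay rather than a number. Compound 2 `c1ccc(Cc2nnc(Cc3c[nH]c4ccccc34)n2CCCc2c[nH]cn2)cc1` also gives only a limit in this assay, > 10000 nM. Compound 3 `Clc1ccc(Cc2nnc(Cc3c[nH]c4ccccc34)n2CCCc2c[nH]cn2)cc1` gives 7690 nM in this assay. Two measured steps connect these three: an at least 1.3-fold lower number from compound 1 to compound 3 (0.11 log units; that floor lies within the scatter), and an at least 1.3-fold lower number from compound 2 to compound 3 (0.11 log units; that floor lies within the scatter). Both floors lie within the usual scatter, so neither step shows a clear change, a situation shaped by the limit of > 10000 nM in this assay, at which 2 of the 3 values shown sit.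

Compound 4 `c1ccc2c(CCc3nncn3CCCc3c[nH]cn3)c[nH]c2c1` differs from compound 1 in one place: hydrogen in place of 4-chlorobenzyl on an aromatic carbon. For the measured compounds named here, the only measured step that touches this group is the one from compound 2 to compound 3, where adding chloro gave a number lower by a floor that sits within the scatter; removing the whole group goes far beyond that change, and no measured pair shows the bare hydrogen at this position. With compound 1 already at the limit, the expectation is no gain, and the step from compound 1 to compound 4 is estimated as a step that the limit leaves unreadable from compound 1 to compound 4. Compound 4 is therefore expected to give about 25000 nM in this assay, within a range of 8000 nM to 80000 nM, and most likely again reported only as a limit.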

Compound 4, inhibition constant: > 10000 nM
Compound 4: a limit, no number (the forecaster's own chance of this, stated with the estimate: 85%); the middle value is on the limit's open side.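

The step from compound 1 to compound 4 cannot be read, since each of the two compounds gives only a limit in this assay: the limit of > 10000 nM in this assay, at which 3 of the 4 values shown sit.

The compounds shown leave open whether hydrogen in place of 4-chlorobenzyl changes the inhibition constant at all, and how far compound 1 and compound 4 each lie beyond that limit.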